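A few compounds are considered here, and "the series" means these few. Any claim that something is new, unique, unknown or untested is made for them only; others in the source may bear on it.

Compound 1 `CCn1ncc2c(F)cc(-c3ccc(C(CC)(CC)c4ncn(C)n4)c(=O)[nH]3)cc21` gives 96 nM in a functional assay on CHO cells for antagonist activity at prostaglandin E2 receptor EP3 subtype (Homo sapiens), read by cAMP accumulation; on this read-out lower numbers stand for stronger inhibition and higher numbers for weaker inhibition.
Compound 2 `CC(C)C(c1ccc(-c2ccc3cccc(F)c3c2)[nH]c1=O)N1CCNC1=O` gives 28 nM in this assay.
Compound 3 `CCn1ncc2c(F)cc(-c3ccc(C(CC)(CC)c4nnc[nH]4)c(=O)[nH]3)cc21` gives 29 nM in this assay.

Compound 2 stands at the lowest of these three numbers, although compound 3 sits within the scatter of it, and only compound 1 lies beyond. Compound 4 `CC(C)C(Nc1nnc[nH]1)c1ccc(-c2ccc3cccc(F)c3c2)[nH]c1=O` differs from compound 2 in one place: (4H-1,2,4-triazol-3-yl)amino in place of 2-oxoimidazolidin-1-yl on a saturated chain carbon bound to an aromatic carbon and a saturated chain carbon. Among the compounds with values here, the one measured step that touches this change is a 3.3-fold lower number from compound 1 to compound 3 (0.52 log units; beyond the scatter), where the same 4H-1,2,4-triazol-3-yl enters, but there it replaced a 1-methyl-1H-1,2,4-triazol-3-yl rather than a 2-oxoimidazolidin-1-yl, so it bears only loosely. Within the data shown here, no step shows a ring of that kind leaving. A step in this assay of at most modest size, if anything toward a lower number, is therefore expected: a 1.3-fold lower number from compound 2 to compound 4 (0.10 log units; within the scatter) is the estimate. Compound 4 is estimated at 22 nM, within 7 nM to 70 nM.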

Compound 4, half-maximal inhibitory concentration: 185 nM
The estimate for compound 4 lay 8.4-fold (0.92 log units) below the measured number; measured number outside the range, above it.
By their numbers in this assay, from the lowest: compounds 2 and 3 (each within the scatter of the next); then compounds 1 and 4 (each within the scatter of the next).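

On a saturated chain carbon bound to an aromatic carbon and a saturated chain carbon, this change gives in this assay a 6.6-fold higher number from compound 2 to compound 4 (0.82 log units; beyond the scatter). The lower number that came with a 4H-1,2,4-triazol-3-yl in a 3.3-fold lower number from compound 1 to compound 3 (0.52 log units; beyond the scatter) therefore does not carry over to this (4H-1,2,4-triazol-3-yl)amino change on the core of compound 2. No measurement at hand explains this rise.

As far as these compounds go, whether the step follows from the triazole ring or from its amino link remains open. So does how an acetamide or a carboxylic acid would fare at this place.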